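A few compounds are considered here, and "the series" means these few. Any claim that something is new, unique, unknown or untested is made for them only; others in the source may bear on it.

Measured so far in a functional assay on SGC-7901 cells (Homo sapiens) for antiproliferative activity, read by MTT assay, with a stated time of 24 h; a lower number here means a stronger inhibitor, a higher number a weaker inhibitor:
- compound 1 `Cc1ccccc1NNC(=O)c1ccc(NS(=O)(=O)c2cnc(O)nc2O)cc1`: > 20000 nM
- compound 2 `Cc1ccccc1C(=O)NNC(=O)c1ccc(NS(=O)(=O)c2cnc(O)nc2O)cc1`: > 20000 nM

Not yet measured: compound 3 `O=C(NNC(=O)c1ccccc1Cl)c1ccc(NS(=O)(=O)c2cnc(O)nc2O)cc1`

Compound 2 reads > 20000 nM in this assay, which is a limit and not a number. Compound 3 differs from compound 2 by chloro in place of methyl on an aromatic carbon, ortho to a large group. For the measured compounds named here, the one measured step, a step that the two limits leave unreadable from compound 1 to compound 2, concerns a different place and offers no size to carry over. Both measured compounds sit at the limit of > 20000 nM in this assay, at which 2 of the 2 values shown sit. With no readable step to lean on, no change beyond the scatter is expected in this assay, and no direction can be argued. The expected result is a step that the limit leaves unreadable from compound 2 to compound 3. For compound 3 the estimated value is 25000 nM, with an expected range of 10000 nM to 50000 nM.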

Compound 3, half-maximal inhibitory concentration: 3240 nM
Beside the measured number, compound 3's estimate is 7.7-fold (0.89 log units) above it; the measured number lies below the stated range.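

In this assay, chloro in place of methyl on an aromatic carbon, ortho to a large group, is the one change shown at this position that gives a readable number, with an at least 6.1-fold lower number from compound 2 to compound 3 (0.79 log units; beyond the scatter). A change of a single heavy atom at this place therefore separates a compound at the limit from a measured one, and replacing 2-methylphenyl on the amine nitrogen with (2-chlorophenyl)carbonyl gives an at least 6.1-fold lower number from compound 1 to compound 3 (0.79 log units; beyond the scatter). Both sizes are only lower bounds, because the starting compounds stand at a limit: the limit of > 20000 nM in this assay, at which 2 of the 3 values shown sit.

From the compounds shown here alone, whether this shift is particular to chloro, or would also appear with fluoro, bromo or methoxy at this place, remains open. Also open, going by these compounds, is whether chloro in place of methyl would lower the number without the carbonyl, as in compound 1.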